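A few compounds are considered here, and "the series" means these few. Any claim that something is new, unique, unknown or untested is made for them only; others in the source may bear on it.

Within the data shown here, compound 2 `CS(=O)(=O)c1ccc(-c2cc(C(O)(C(F)(F)F)C(F)(F)F)cnc2N2CCN(S(=O)(=O)c3ccc(N)nc3)CC2)cc1` sits at the low end of the two numbers so far: in an ADME assay (liver) for metabolic stability, with Liver microsome (Homo sapiens) as the target, using microsomes and NADPH, with a stated time of 30 min, tested at 1 uM (on this read-out higher numbers stand for fast clearance and lower numbers for slow clearance), compound 2 gives 32 mL.min-1.g-1, while compound 1 `CC(C)(C)n1cc(-c2cc(C(O)(C(F)(F)F)C(F)(F)F)cnc2N2CCN(S(=O)(=O)c3ccc(N)nc3)CC2)cn1` gives 86 mL.min-1.g-1. Compound 3 `Nc1ccc(S(=O)(=O)N2CCN(c3ncc(C(O)(C(F)(F)F)C(F)(F)F)cc3-c3ccc4scnc4c3)CC2)cn1` carries the change (1,3-benzothiazol-5-yl in place of 4-(methylsulfonyl)phenyl on an aromatic carbon). Among the measured compounds shown here, the one measured step that bears on it is a 2.7-fold lower number from compound 1 to compound 2 (0.43 log units; beyond the scatter), which came with the arrival of the 4-(methylsulfonyl)phenyl group, and in compound 3 that group leaves again. The change is therefore expected to run the other way, and the expected step is only a modest one, a 1.7-fold higher number from compound 2 to compound 3 (0.24 log units; within the scatter). Compound 3 is thus estimated at 55 mL.min-1.g-1, with a range from 25 mL.min-1.g-1 to 120 mL.min-1.g-1.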

Compound 3, intrinsic clearance in microsomes: 39 mL.min-1.g-1
For compound 3 the middle estimate is 1.4-fold (0.15 log units) above the measured one; the range from low to high includes it.
By their numbers in this assay, from the lowest: compounds 2 and 3 (each within the scatter of the next); then compound 1.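

In this assay, this position, on an aromatic carbon of a six-membered aromatic ring with 1 nitrogen, takes a second, quite different group without a change beyond the scatter: a 1.2-fold higher number from compound 2 to compound 3 (0.09 log units; within the scatter). The lower number therefore does not require the 4-(methylsulfonyl)phenyl group, since 1,3-benzothiazol-5-yl also gives a 2.2-fold lower number from compound 1 to compound 3 (0.34 log units; beyond the scatter). Nothing shown gives a reason for either step. The compounds shown leave open whether a plain phenyl or a morpholine at this position would give a number in the same range. They also leave open whether a 1-methyl-1H-pyrazol-4-yl group would stay near compound 1.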